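The source may report more compounds than this note shows. Statements on the series, on what has been measured and on what is new or still open speak of the compounds shown alone.

In a functional assay on the whole organism (COLO 205 cells) for inhibition, with Mus musculus as the target, read by polymerase chain reaction, in a xenograft, with a stated time of 8 h, at a dose of 40 mg/kg by the oral route (a higher number here means more inhibition at the dose given (going by the name of the read-out), a lower number less inhibition), the two measured compounds gave these numbers:

Compound 1 `Cc1cc(C)c(-c2cn(C)cn2)cc1NC(=O)c1ccc(OCc2ccccn2)cc1`: 87%
Compound 2 `Cc1cc(F)c(-c2ncc[nH]2)cc1NC(=O)c1ccc(OCc2ccccn2)cc1`: 73%

Compound 1 stands highest of the two; compound 2 is the nearer neighbour, and the gap between them lies beyond the usual scatter of repeated measurements.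

Compound 3 `Cc1cc(C)c(-c2c[nH]nc2C)cc1NC(=O)c1ccc(OCc2ccccn2)cc1` has not been measured. Compared with compound 1 it differs in one place (3-methyl-1H-pyrazol-4-yl in place of 1-methyl-1H-imidazol-4-yl on an aromatic carbon). Among the compounds with values here, nothing among the measured pairs shows a step of this kind, so no direct guide to its size exists. The ring that enters is of the same size and carries the same number of heavy atoms as the one that leaves, and the two compounds agree everywhere else. A small step is therefore expected, most likely a slight loss in this assay, though a step within the scatter cannot be ruled out: the step from compound 1 to compound 3 is estimated as a number 9 percentage points lower from compound 1 to compound 3 (within the scatter). Compound 3 is thus expected to give about 78%, within a range from 60% to 92%.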

Compound 3, a percentage reported as inhibition, in the whole organism at one dose (the size of the read-out at that dose, not a potency): 75%
Beside the measured number, compound 3's estimate is 3 percentage points above it; low and high end bracket the measured number.
By their numbers in this assay, from the lowest: compounds 2 and 3 (each within the scatter of the next); then compound 1.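

Within the data shown here, this is the first comparison that changes only one place: with the same atoms joined differently, putting 3-methyl-1H-pyrazol-4-yl in place of 1-methyl-1H-imidazol-4-yl on this aromatic carbon gives, in this assay, a number 12 percentage points lower from compound 1 to compound 3 (beyond the scatter). The position therefore accepts a different five-membered aromatic ring while keeping clear inhibition, with compound 3 at 75%, but the exact ring is not a matter of indifference. The entering ring has 1 hydrogen-bond donor and 1 hydrogen-bond acceptor, against 0 donors and 2 acceptors in the leaving ring, but no measurement here ties the step to this difference or to any other cause.

The compounds shown leave open how a pyridine ring or a simple amine would fare at this position. Also open, as far as these compounds go, is whether this step would keep its size at another dose or time.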